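Thiophene to Furan on the Shared Core

This account rests on a few compounds, and the source may have more. Where it says the series, first, only, none or still open, it means among the compounds named here.

Among the compounds with values here, compound 2, `O=C(O)c1cccc(Cc2c(-c3cccs3)nn3cc(Cl)ccc23)n1`, is the weaker of the two compounds measured so far: in a functional assay on cells for antagonist activity at prostaglandin E2 receptor EP1 subtype (Rattus norvegicus), read by fluorescence and calcium flux, with a stated time of 60 s (a higher number here means a weaker inhibitor, a lower number a stronger inhibitor), compound 2 gives 1100 nM. Its nearest neighbour, compound 1, `O=C(O)c1cccc(Cc2c(-c3ccccc3)nn3cc(F)ccc23)n1`, gives 380 nM in this assay, a gap beyond the usual scatter. Within the data shown here, the two compounds differ in more than one place, so no single step between them can be read off, and only their two values can be compared.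

Compound 3, `O=C(O)c1cccc(Cc2c(-c3ccoc3)nn3cc(Cl)ccc23)n1`, is compound 2 with furan-3-yl in place of thiophen-2-yl on an aromatic carbon. Among the measured compounds shown here, no measured pair shows what this exchange does in this assay, and the comparison between compound 1 and compound 2 does not isolate it. The change from compound 2 to compound 3 is therefore expected to be small, near the scatter, with no firm direction. Its estimated size, a 1.4-fold higher number from compound 2 to compound 3 (0.13 log units; within the scatter), leans toward a slight weakening. Compound 3 is expected to give 1500 nM in this assay, within a range from 600 nM to 4000 nM.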

Compound 3, half-maximal inhibitory concentration: 130 nM
Compound 3: middle estimate off by 12-fold (1.06 log units), on the high side; measured number outside the range, below it.
By their numbers in this assay, from the lowest: compound 3; then compound 1; then compound 2.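

Within the data shown here, at this position, on an aromatic carbon of a five-membered aromatic ring with 2 nitrogen, the exchange of thiophen-2-yl for furan-3-yl gives in this assay an 8.5-fold lower number from compound 2 to compound 3 (0.93 log units; beyond the scatter), so the first step that can be read here is a clear one rather than a change near the scatter. Thiophen-2-yl and furan-3-yl have the same counts of heavy atoms, hydrogen-bond donors and hydrogen-bond acceptors, and neither carries a net charge, which shows that the value at this place can shift markedly between groups those counts do not tell apart. No measurement of any property of these two groups bears on the step, which therefore stands as an observation without an explanation.

The step changes the hetero atom from sulfur to oxygen and the point of attachment on the ring together, and only thiophen-3-yl and furan-2-yl would show how much of it belongs to each. On these data alone, whether the same exchange would hold with fluorine in place of the chlorine on the shared core also remains open, as does the effect of a larger group here, such as a methyl-substituted furan.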